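This account rests on a few compounds, and the source may have more. Where it says the series, first, only, none or still open, it means among the compounds named here.

Measured so far:
Compound 1, `O=C(N[C@@H](CO)C(=O)NO)c1ccc(C#Cc2ccccc2)cc1`: 2
Compound 2, `CC(NC(=O)c1ccc(C#Cc2ccccc2)cc1)C(=O)NO`: > 3
Compound 3, `O=C(NC1(C(=O)NO)CCSCC1)c1ccc(C#Cc2ccccc2)cc1`: > 3

Within the data shown here, in a physicochemical assay for lipophilicity (on this read-out lower numbers stand for lower lipophilicity and higher numbers for higher lipophilicity), compound 1 gives 2, the only plain number among the three. In this assay compound 2 reaches only a limit, > 3. Compound 3 likewise sits at a limit, > 3. Among the measured compounds shown here, the one step that can be sized, a number at least 1.00 log units higher from compound 1 to compound 2 (beyond the scatter), puts a group of 6 heavy atoms in place of a group of 7 heavy atoms on an amide-type nitrogen, and its size is known only as a bound because of the limit of > 3 in this assay, at which 2 of the 3 values shown sit.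

Compound 4, `O=C(C[C@H](NC(=O)c1ccc(C#Cc2ccccc2)cc1)C(=O)NO)NCCCO`, differs from compound 1 by (3-hydroxypropyl)carbamoyl in place of hydroxy on a saturated chain carbon, two bonds along the chain from an amide-type nitrogen and a carbonyl carbon. For the measured compounds named here, no measured step covers this change: the step from compound 1 to compound 2 removes a hydroxy and rises, whereas here a hydroxy leaves and a (3-hydroxypropyl)carbamoyl, carrying its own donors and acceptors, enters on the saturated chain carbon two bonds along the chain from an amide-type nitrogen and a carbonyl carbon. The step is therefore expected to be small, a number 0.20 log units lower from compound 1 to compound 4 (within the scatter), perhaps no more than the scatter and, if anything, downward. Compound 4 is thus estimated at 1.8, in the range 1.2 to 2.4.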

Compound 4, distribution coefficient: 2
Beside the measured number, compound 4's estimate is 0.20 log units below it; low and high end bracket the measured number.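

In this assay, putting (3-hydroxypropyl)carbamoyl in place of hydroxy on the saturated chain carbon gives no change at the digits printed from compound 1 to compound 4 (within the scatter). Among these compounds, until now, the only step that could be sized at this place was a number at least 1.00 log units higher from compound 1 to compound 2 (beyond the scatter), so this position has now given one step beyond the scatter and one within it. The 7 heavy atoms of the entering group, with its 2 hydrogen-bond donors and 2 hydrogen-bond acceptors, therefore leave the number in place in this one case, and a larger group here need not move the read-out.

From the compounds shown here alone, whether an amine, a carboxylic acid or a plain longer alkyl chain on the same carbon would also leave this assay unmoved remains open. The steps involving compound 3 cannot be read, and the step to compound 2 has no known upper end: the limit of > 3 in this assay, at which 2 of the 4 values shown sit.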